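Methyl on the Imidazole Carbon: From Compound 3 to Compound 4

The source may hold more compounds than are shown below. What is called first, only, known or untested is meant among the compounds shown, and "the series" means these compounds.

Compound 1 `CC(C#CCn1ccnc1)N1CCCC1=O` and compound 2 `Cc1cncn1CC#CC(C)N1CCCC1=O` share one core, while compound 3 `O=C1OCCN1CC#CCn1ccnc1` is built on another; the difference between the two cores is not broken down here. In a functional assay on the whole organism for agonist activity, with Mus musculus as the target (a lower number here means that less compound is needed, a higher number that more compound is needed for the effect), compound 1 gives > 100 mg/kg, which is a limit of the assay rather than a number. In this assay compound 2 likewise gives > 100 mg/kg, again a limit. In this assay, going by the values given here, compound 3 gives 2 mg/kg, the only number among the three measured values. The change from compound 1 to compound 2, (methyl in place of hydrogen on an aromatic carbon), produced a step that the two limits leave unreadable from compound 1 to compound 2, since both values sit at the limit of > 100 mg/kg in this assay, at which 2 of the 3 values shown sit.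

Compound 4 `Cc1cncn1CC#CCN1CCOC1=O` carries the same change on the core of compound 3: methyl in place of hydrogen on an aromatic carbon. The measured step from compound 1 to compound 2 is unreadable. It gives no guide to the size of the same change on the core of compound 3. The writer therefore expects a modest step of a 1.5-fold higher number from compound 3 to compound 4 (0.18 log units; within the scatter) from compound 3 to compound 4. Compound 4 is estimated at 3 mg/kg, with a likely range from 1 mg/kg to 15 mg/kg.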

Compound 4, dose for half-maximal effect: > 100 mg/kg
Compound 4 ended at the assay's limit; the forecaster's own chance of this, stated with the estimate: 15%; at least 33-fold (1.52 log units) between middle value and limit.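

In this assay, methyl in place of hydrogen on an aromatic carbon gives an at least 50-fold higher number from compound 3 to compound 4 (1.69 log units; beyond the scatter), so on the core of compound 3 this single added carbon costs nearly all of the measurable effect. Compound 4 gives > 100 mg/kg, which is a limit of the assay and not a number. The same change on the other core cannot be read, so the series shows a large step on one core only and does not show whether the change acts alike on both, since the values there offer no size to compare: the limit of > 100 mg/kg in this assay, at which 3 of the 4 values shown sit.

The compounds shown leave open whether this loss belongs to methyl alone or would also follow another group on the same aromatic carbon, such as chlorine, an ethyl chain or an amine. They also leave open whether any change to the core of compound 1 would bring its value off the limit, so that the effect of methyl could be sized there.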